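Swapping Methyl for Trifluoromethyl in a Small Antiproliferative Series

A few compounds are considered here, and "the series" means these few. Any claim that something is new, unique, unknown or untested is made for them only; others in the source may bear on it.

Of the compounds shown here, two with a shared core have been measured so far: compound 1 `CNc1nc(-c2cc(OC)c(OC)c(OC)c2)c(-c2ccc3ccccc3c2)s1` and compound 2 `CNc1nc(-c2cc(OC)c(OC)c(OC)c2)c(-c2ccc(C)cc2)s1`. In a functional assay on HT-29 cells (Homo sapiens) for antiproliferative activity, read by MTT assay, with a stated time of 72 h (a higher number here means a weaker inhibitor, a lower number a stronger inhibitor), compound 1 gives 38.2 nM, while compound 2 gives 423 nM. Compound 2 therefore has the higher number of the pair, making it the weaker inhibitor, and the gap between them lies well beyond the usual scatter of repeated measurements.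

The next compound, compound 3 `CNc1nc(-c2cc(OC)c(OC)c(OC)c2)c(-c2ccc(C(F)(F)F)cc2)s1`, differs from compound 2 at one place: trifluoromethyl in place of methyl on an aromatic carbon. In words, trifluoromethyl stands in place of methyl on an aromatic carbon, para to a large group. For the measured compounds named here, no measured pair here shows this swap, so the forecast rests on very little evidence. A modest loss of strength in this assay seems more likely than a gain, though no change beyond the scatter remains quite possible. The expected change is a 2.0-fold higher number from compound 2 to compound 3 (0.30 log units; within the scatter), a small move toward a higher number. Compound 3 is estimated at 850 nM, with an expected range of 250 nM to 3000 nM.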

Compound 3, half-maximal inhibitory concentration: 1240 nM
Compound 3: middle estimate off by 1.5-fold (0.16 log units), on the low side; the range from low to high includes it.
By their numbers in this assay, from the lowest: compound 1; then compound 2; then compound 3.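

In this assay, the group at this position matters even when the change is small: trifluoromethyl in place of methyl on an aromatic carbon, para to a large group, gives a 2.9-fold higher number from compound 2 to compound 3 (0.47 log units; beyond the scatter) and so a weaker inhibitor. For the compounds shown here, this is the first measured pair that differs in one place, so the effect of this swap now rests on a direct comparison, and the step is modest in size but beyond the usual scatter. Going by these compounds alone, with only this pair, the data tie the weaker result to the swap itself and give no measurement that could explain it.

From the compounds shown here alone, it remains open whether the number follows the count of heavy atoms, which rises from 1 in methyl to 4 in trifluoromethyl, or depends on something else about the group, and a chlorine atom, an amine or a longer chain such as ethyl at this place could help separate those readings. A single pair also cannot show whether the same swap would shift the number in the same direction on a different core.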